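The source may hold more compounds than are shown below. What is called first, only, known or untested is meant among the compounds shown, and "the series" means these compounds.

Working notes on the series. In a functional assay on SF-295 cells (Homo sapiens) for antiproliferative activity (a higher number here means a weaker inhibitor of growth, a lower number a stronger inhibitor of growth), compound 1 `Cc1cnc2nc(-c3ccc4ccccc4c3)cc(O)c2c1` gives 550 nM and compound 2 `Cc1ccc2c(O)cc(-c3cccc(Cl)c3)nc2n1` gives 22.9 nM. Compound 3 `Cc1cc(C)c2c(O)cc(-c3ccc4ccccc4c3)nc2n1` gives 14800 nM in this assay, the highest of the three numbers; the gap to compound 1 and the far larger gap to compound 2 both lie beyond the scatter, so compound 3 is the weakest growth inhibitor measured here. Compound 4 `Cc1ccnc2nc(-c3ccc4ccccc4c3)cc(O)c12` is not yet measured. It differs from compound 3 in one place: hydrogen in place of methyl on an aromatic carbon, the carbon lost sitting next to the ring nitrogen. Within the data shown here, no measured pair shows this change alone. Since compound 1, which also carries a single methyl, gives 550 nM, the step is expected to lower the number, about a 9.9-fold lower number from compound 3 to compound 4 (0.99 log units; beyond the scatter), though its size remains uncertain. Compound 4 is estimated at 1500 nM, within 300 nM to 8000 nM.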

Compound 4, concentration for 50% growth inhibition: 1480 nM
For compound 4 the middle estimate is 1.0-fold (0.01 log units) above the measured one, within the range that was stated.
By their numbers in this assay, from the lowest: compound 2; then compound 1; then compound 4; then compound 3.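

Among these compounds, this is the first comparison that differs in one place. In this assay, replacing the methyl next to the ring nitrogen with hydrogen gives a 10-fold lower number from compound 3 to compound 4 (1.00 log units; beyond the scatter), so a methyl on this aromatic carbon alone is enough to weaken growth inhibition. No measurement available here bears on the reason for this step.

On these data alone, whether an amine, a methoxy group or a longer chain on this carbon would shift the number in the same direction stays open. Also open, as far as these compounds go, is whether the step holds with the chlorophenyl group of compound 2 in place of the aryl group of compound 4.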